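From Chloro to Nitro on a Shared Core

The source may hold more compounds than are shown below. What is called first, only, known or untested is meant among the compounds shown, and "the series" means these compounds.

Of the compounds shown here, three sharing one core have been measured in a functional assay on HeLa cells (Homo sapiens) for inhibition, read by MTT assay, with a stated time of 48 h; on this read-out higher numbers stand for weaker inhibition and lower numbers for stronger inhibition. Compound 1 (`Oc1ccc(C(c2c[nH]c3ccc(Br)cc23)c2c[nH]c3ccc(Br)cc23)cc1`) gives 4000 nM, compound 2 (`Oc1cccc(C(c2c[nH]c3ccc(Br)cc23)c2c[nH]c3ccc(Br)cc23)c1`) gives 3900 nM and compound 3 (`Clc1ccc(C(c2c[nH]c3ccc(Br)cc23)c2c[nH]c3ccc(Br)cc23)cc1`) gives 4800 nM. Compound 3 thus lies within the scatter of both others. The next compound, compound 4 (`O=[N+]([O-])c1ccc(C(c2c[nH]c3ccc(Br)cc23)c2c[nH]c3ccc(Br)cc23)cc1`), carries nitro in place of chloro on an aromatic carbon, para to a large group: nitro in place of chloro on an aromatic carbon. The closest evidence comes from the measured exchanges on the same ring. Chloro in place of hydroxy gave a 1.2-fold higher number from compound 1 to compound 3 (0.08 log units; within the scatter), and 4-chlorophenyl in place of 3-hydroxyphenyl gave a 1.2-fold higher number from compound 2 to compound 3 (0.09 log units; within the scatter). Moving the hydroxy group gave a 1.0-fold lower number from compound 1 to compound 2 (0.01 log units; within the scatter). Starting from compound 3 at 4800 nM, no step beyond the scatter is expected in this assay, although no nitro compound has yet been measured here. The estimated change is a 1.2-fold lower number from compound 3 to compound 4 (0.08 log units; within the scatter). Compound 4 is expected at 4000 nM, with an estimated range of 1800 nM to 9000 nM.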

Compound 4, half-maximal inhibitory concentration: 1500 nM
Beside the measured number, compound 4's estimate is 2.7-fold (0.43 log units) above it; the whole stated range lies above it.
By their numbers in this assay, from the lowest: compound 4; then compounds 2, 1 and 3 (each within the scatter of the next).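

In this assay, this position proves able to respond to a single exchange: nitro in place of chloro gives a 3.2-fold lower number from compound 3 to compound 4 (0.51 log units; beyond the scatter) whereas the earlier exchanges on this ring all stayed within the scatter. The shift holds against both hydroxy compounds, with nitro in place of hydroxy giving a 2.7-fold lower number from compound 1 to compound 4 (0.43 log units; beyond the scatter) and 4-nitrophenyl in place of 3-hydroxyphenyl giving a 2.6-fold lower number from compound 2 to compound 4 (0.41 log units; beyond the scatter) so that compound 4 stands apart from the other three, which do not separate from one another. Nothing available explains why nitro behaves differently from chloro and hydroxy.

As far as these compounds go, whether this step is particular to nitro remains open, and a nitrile or an amine in the same place could test that. Also open, from the compounds shown here alone, is whether nitro would give a similar number in the place that the hydroxy group holds in compound 2.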